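This account rests on a few compounds, and the source may have more. Where it says the series, first, only, none or still open, it means among the compounds named here.

Of the compounds shown here, three sharing one core have been tested in a functional assay on HCT-8 cells (Homo sapiens) for cytotoxicity; a higher number here means that more compound is needed for the effect, a lower number that less compound is needed. Compound 1 `Oc1cc(-c2ccccc2)nc2c(O)cccc12` gives a value of > 10 ug/mL in this assay, which is a limit of the assay rather than a measured number. Compound 2 `Oc1cc(-c2ccccc2)nc2cc(F)ccc12` gives 3.45 ug/mL in this assay. Compound 3 `CCCCOc1cc(-c2ccccc2)nc2ccccc12` gives > 10 ug/mL in this assay, which is again a limit and not a number. Compound 3 thus stands at the limit of > 10 ug/mL in this assay, at which 2 of the 3 values shown sit, and what lies past that limit for compound 3 is not known. Among the measured compounds shown here, no two of the measured compounds differ in only one place, so no measured step of the kind that would anchor a prediction is available.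

Compound 4 `CC(C)Oc1cc(-c2ccccc2)nc2ccccc12` has not yet been measured. It differs from compound 3 by isopropyl in place of butyl on an oxygen on an aromatic ring. The step from compound 3 to compound 4 in this assay is expected to be none beyond the scatter, at a step that the limit leaves unreadable from compound 3 to compound 4. Compound 4 is therefore estimated to give 12 ug/mL in this assay, with a range from 4 ug/mL to 40 ug/mL.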

Compound 4, half-maximal effective concentration: 10 ug/mL
Compound 4: middle estimate off by 1.2-fold (0.08 log units), on the high side; low and high end bracket the measured number.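

In this assay, isopropyl in place of butyl on the oxygen gives a number no higher from compound 3 to compound 4 (the limit leaves the size open). Compound 4 gives 10 ug/mL, so a group on this oxygen now has a readable number, and that number sits right at the edge of the range that could be read for compound 3. The value of compound 3, > 10 ug/mL, is a limit and not a number, so this change could be very small or much larger: the limit of > 10 ug/mL in this assay, at which 2 of the 4 values shown sit.

The compounds shown leave open whether a still shorter group on this oxygen, such as methyl, would bring the number down, or whether a chain ending in an amine would do so. They also leave open how far past its limit the butyl compound lies.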